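The source may hold more compounds than are shown below. What is called first, only, known or untested is meant among the compounds shown, and "the series" means these compounds.

In a functional assay on MT4 cells (Homo sapiens) for cytotoxicity, read by MTT assay (on this read-out lower numbers stand for higher toxicity in this test and higher numbers for lower toxicity in this test), compound 1 (`Cc1c(O)nc(SCc2ccc(Cl)cc2)nc1Cc1c(Cl)cccc1Cl`) gives > 59000 nM as a limit of the assay, not a number. Compound 2 (`CCOc1ccc(CSc2nc(O)c(C)c(Cc3c(Cl)cccc3Cl)n2)cc1`) gives > 58000 nM and this too is only a limit. Compound 3 (`CCCCOc1ccc(CSc2nc(O)c(C)c(Cc3c(Cl)cccc3Cl)n2)cc1`) extends the ethoxy to butoxy (ethyl in place of hydrogen on a saturated chain carbon, two bonds along the chain from an oxygen on an aromatic ring). Among the measured compounds shown here, the one measured step (a step that the two limits leave unreadable from compound 1 to compound 2) offers no size to carry forward, so no shift beyond the scatter is expected in this assay for this change. The estimated step (an at least 1.1-fold lower number from compound 2 to compound 3 (0.06 log units; that floor lies within the scatter)) is therefore expected to stay small. Compound 3 is estimated at 50000 nM within an expected range of 20000 nM to 70000 nM, and a limit of the assay is again expected.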

Compound 3, half-maximal cytotoxic concentration: 3100 nM
Compound 3: middle estimate off by 16-fold (1.21 log units), on the high side; the whole stated range lies above it.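

In this assay going from ethoxy to butoxy at this chain end turns a limit into a readable value, with (an at least 18-fold lower number from compound 2 to compound 3 (1.27 log units; beyond the scatter)). Butoxy in place of chloro on the aromatic carbon likewise gives (an at least 19-fold lower number from compound 1 to compound 3 (1.27 log units; beyond the scatter)). The first of these sizes is only a floor because compound 2 gives a limit of the assay, not a number: the limit of > 58000 nM in this assay, at which 1 of the 3 values shown sits.

As far as these compounds go, whether the number falls further with a longer chain such as hexyloxy remains open. So does how an amine at the end of this chain would behave.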